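Nitro at the ring carbon of compound 3

The compounds below may be only part of what the source reports. "The series", "measured", "known", "first", "only" and "open" are said of these compounds alone.

Of the compounds shown here, three sharing one core have been measured in an ADME assay on MRC5 cells (Homo sapiens) for cytotoxicity; on this read-out lower numbers stand for stronger inhibition and higher numbers for weaker inhibition. Compound 1 `COc1ccc(Cn2cc(CNC(=O)c3ccc([N+](=O)[O-])o3)nn2)cc1F` gives 324000 nM. Compound 2 `COc1ccc(Cn2cc(CNC(=O)c3ccc([N+](=O)[O-])o3)nn2)cc1O` gives 189000 nM. Compound 3 `COc1ccc(Cn2cc(CNC(=O)c3ccc([N+](=O)[O-])o3)nn2)cc1` gives 146000 nM, the lowest number of the three, though compound 2 sits within the scatter of it. Among the steps, a 2.2-fold lower number from compound 1 to compound 3 (0.35 log units; beyond the scatter) and a 1.3-fold lower number from compound 2 to compound 3 (0.11 log units; within the scatter), while a 1.7-fold lower number from compound 1 to compound 2 (0.23 log units; within the scatter).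

Compound 4 `COc1ccc(Cn2cc(CNC(=O)c3ccc([N+](=O)[O-])o3)nn2)cc1[N+](=O)[O-]` differs from compound 3 by nitro in place of hydrogen on an aromatic carbon; the new group sits on an aromatic carbon of a six-membered aromatic ring of carbon only, ortho to a methoxy group and meta to a large group. Among the compounds with values here, the steps that bear on this change are those at the same carbon: replacing hydrogen by fluoro or hydroxy moved the number in this assay only modestly or not beyond the scatter. Compound 4 is therefore expected to give a number near that of compound 3 or somewhat higher, with a 1.3-fold higher number from compound 3 to compound 4 (0.11 log units; within the scatter) as the expected step. The estimate for compound 4 is 190000 nM, within the range 90000 nM to 400000 nM.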

Compound 4, half-maximal inhibitory concentration: 198000 nM
Beside the measured number, compound 4's estimate is 1.0-fold (0.02 log units) below it; low and high end bracket the measured number.
By their numbers in this assay, from the lowest: compounds 3, 2, 4 and 1 (each within the scatter of the next, the first and the last beyond it).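

At this carbon, ortho to a methoxy group, nitro brings in 3 heavy atoms, yet in this assay the step from hydrogen stays within the scatter (a 1.4-fold higher number from compound 3 to compound 4 (0.13 log units; within the scatter)). The comparisons with the other groups at the same carbon also stay within the scatter (a 1.0-fold higher number from compound 2 to compound 4 (0.02 log units; within the scatter); a 1.6-fold lower number from compound 1 to compound 4 (0.21 log units; within the scatter)), so nitro cannot be told apart from hydrogen, hydroxy or fluoro here, even though hydrogen and fluoro do stand apart from each other. Nothing measured here offers an explanation for this result.

The compounds shown leave open whether another kind of group at this carbon, such as an amine, a carboxylic acid or a longer alkoxy chain, would move the number beyond the scatter. They also leave open whether nitro elsewhere on the six-membered aromatic ring would give a similar number.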